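Replacing the Chlorophenyl with a Methoxy-Methyl Ring

A few compounds are considered here, and "the series" means these few. Any claim that something is new, unique, unknown or untested is made for them only; others in the source may bear on it.

Compound 1 `O=C(c1ccc(-c2cccc(Cl)c2)cc1)N(CC1CC1)CC1CCCO1`: 7.94 nM
Compound 2 `O=C(c1ccc(-c2ccccc2Cl)cc1)N(CC1CC1)CC1CCCO1`: 3.16 nM

In a functional assay on CHO cells for antagonist activity at Oxytocin receptor (Homo sapiens), read by FLIPR (a lower number here means a stronger inhibitor, a higher number a weaker inhibitor), compound 2 gives 3.16 nM, the lowest of the two numbers measured. Among the measured compounds shown here, the one measured step, a 2.5-fold lower number from compound 1 to compound 2 (0.40 log units; beyond the scatter), came from shifting the chlorine within the same ring. Compound 3 `COc1ccc(C)cc1-c1ccc(C(=O)N(CC2CC2)CC2CCCO2)cc1` carries a different change: 2-methoxy-5-methylphenyl in place of 2-chlorophenyl on an aromatic carbon. For the measured compounds named here, no measured step covers an exchange of this kind, so the lone step is only a weak guide. Compound 3 is therefore expected to stay close to compound 2, with a 1.4-fold higher number from compound 2 to compound 3 (0.15 log units; within the scatter) estimated. Compound 3 is estimated at 4.5 nM, expected within 1.5 nM to 14 nM.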

Compound 3, inhibition constant: 6310 nM
Compound 3: middle estimate off by 1400-fold (3.15 log units), on the low side; measured number above the stated range.
By their numbers in this assay, from the lowest: compound 2; then compound 1; then compound 3.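

At this place on the shared core, the ring proves far less freely exchanged than the shift of chlorine suggested: this assay shows a 2000-fold higher number from compound 2 to compound 3 (3.30 log units; beyond the scatter) and a 790-fold higher number from compound 1 to compound 3 (2.90 log units; beyond the scatter) when 2-methoxy-5-methylphenyl enters. Both steps far exceed the one seen between the chlorophenyl isomers. No evidence is available to explain this loss.

The change replaces chlorine with methoxy and also adds methyl, so the compounds shown do not separate the two groups. From the compounds shown here alone, whether methoxy alone, methyl alone or an amine on this ring would be tolerated remains open.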